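This account rests on a few compounds, and the source may have more. Where it says the series, first, only, none or still open, it means among the compounds named here.

Measured in a physicochemical assay for solubility, in phosphate buffer, measured as kinetic solubility, with a stated time of 24 h, at pH 6.5; on this read-out higher numbers stand for higher solubility and lower numbers for lower solubility:
- Compound 1 `CC(C)Oc1cc(Oc2ccc(S(C)(=O)=O)cc2)cc(-c2cncc(=O)[nH]2)c1`: 118000 nM
- Compound 2 `CCc1cnc(-c2cc(Oc3ccc(S(C)(=O)=O)cc3)cc(OC(C)C)c2)[nH]c1=O`: 5700 nM

Not yet measured:
- Compound 3 `CC(C)Oc1cc(Oc2ccc(S(C)(=O)=O)cc2)cc(-c2ncc(Cl)c(=O)[nH]2)c1`

Compound 2 holds the lower of the two numbers. The structural change to compound 3 is chloro in place of ethyl on an aromatic carbon, with chloro in place of ethyl on an aromatic carbon. Among the compounds with values here, only one measured step bears on it, and only indirectly: a 21-fold lower number from compound 1 to compound 2 (1.32 log units; beyond the scatter), which is large and replaces a whole group. Since that step covers more than the ethyl exchange, a smaller move towards higher numbers is expected in this assay. The expected step is a 2.6-fold higher number from compound 2 to compound 3 (0.42 log units; beyond the scatter). For compound 3 the estimated value is 15000 nM, with an expected range of 5000 nM to 50000 nM.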

Compound 3, solubility: 24000 nM
Beside the measured number, compound 3's estimate is 1.6-fold (0.20 log units) below it; the range from low to high includes it.
By their numbers in this assay, from the lowest: compound 2; then compound 3; then compound 1.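

In this assay, with the rest of the group held the same, chloro in place of ethyl gives a 4.2-fold higher number from compound 2 to compound 3 (0.62 log units; beyond the scatter), so the substituent on this aromatic carbon alone moves the read-out beyond the scatter, which the earlier whole-group exchange could not show. The chloro-bearing group still gives a 4.9-fold lower number from compound 1 to compound 3 (0.69 log units; beyond the scatter), a step that replaces a whole group and so does not isolate this position. No measurement here accounts for either step. Still open, going by these compounds, is how a methoxy group or an amine on this aromatic carbon would read.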